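Dropping one methoxy from compound 2

The source may report more compounds than this note shows. Statements on the series, on what has been measured and on what is new or still open speak of the compounds shown alone.

In a functional assay on DU-145 cells (Homo sapiens) for cytotoxicity, read by MTT assay, with a stated time of 72 h (on this read-out lower numbers stand for stronger inhibition and higher numbers for weaker inhibition), compound 1 `Cc1cc(/C=C/c2ccc(O)cc2)[nH]n1` gives 45800 nM as a measured number. Compound 2 `COc1ccc(/C=C/c2cc(C)no2)cc1OC` reads > 100000 nM and this is a limit of the assay, so it has no number of its own. Compound 3 `COc1ccc(/C=C/C(=O)CC(C)=O)cc1OC` gives 8200 nM as a measured number.

For the measured compounds named here, the only measured step is an at least 12-fold lower number from compound 2 to compound 3 (1.08 log units; beyond the scatter) and it replaces the 3-methyl-1,2-oxazol-5-yl group while both methoxy groups stay in place. It therefore gives no direct size for a methoxy change.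

Compound 4 `COc1ccc(/C=C/c2cc(C)no2)cc1` differs from compound 2 by hydrogen in place of methoxy on an aromatic carbon in one change: hydrogen in place of methoxy on an aromatic carbon, ortho to a methoxy group. Going by the values given here, with no measured step at this place, a large change is not expected, and a second reading at the limit in this assay is somewhat more likely than a number.

The expected change is an at least 1.1-fold lower number from compound 2 to compound 4 (0.04 log units; that floor lies within the scatter) and it is an estimate close to the limit, not a measured gain. The lower end of the range stays near compound 1 at 45800 nM as the closest measured number among the compounds without the open chain of compound 3. Compound 4 is estimated at 90000 nM with 35000 nM to 150000 nM as the expected range.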

Compound 4, half-maximal inhibitory concentration: > 100000 nM
Compound 4 gave a limit, no number (the forecaster's own chance of this, stated with the estimate: 55%); middle value at least 1.1-fold (0.04 log units) from the limit.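

Compound 2 and compound 4 both read as limits of the assay rather than numbers, so the step between them cannot be read: the limit of > 100000 nM in this assay, at which 2 of the 4 values shown sit. The compounds shown leave open whether hydrogen in place of methoxy on an aromatic carbon changes the read-out at all in this pair carrying the 3-methyl-1,2-oxazol-5-yl group, and by how much.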